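The source may report more compounds than this note shows. Statements on the series, on what has been measured and on what is new or still open speak of the compounds shown alone.

In a functional assay on CCRF-CEM cells (Homo sapiens) for antiproliferative activity (on this read-out lower numbers stand for higher toxicity in this test and higher numbers for lower toxicity in this test), compound 1 (`Cc1cn(C2OC(CO[Si](C)(C)C(C)(C)C)C3(OS(=O)(=O)C=C3N)C2O[Si](C)(C)C(C)(C)C)c(=O)n(CCCNC(=O)[C@@H]2CCCN2C(=O)[C@@H](N)C(C)C)c1=O`) gives 10000 nM and compound 2 (`Cc1cn(C2OC(CO[Si](C)(C)C(C)(C)C)C3(OS(=O)(=O)C=C3N)C2O[Si](C)(C)C(C)(C)C)c(=O)n(CCCNC(=O)[C@@H]2CCCN2C(=O)[C@H](C)N)c1=O`) gives 19000 nM while compound 3 (`Cc1cn(C2OC(CO[Si](C)(C)C(C)(C)C)C3(OS(=O)(=O)C=C3N)C2O[Si](C)(C)C(C)(C)C)c(=O)n(CCCNC(=O)[C@H]2CCCN2C(=O)[C@@H](N)C(C)C)c1=O`) gives 11000 nM as its number. All three share one core, and compound 3 stands together with the other two: every gap among them lies within the scatter, so no order can be read from these numbers.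

Compound 4 (`Cc1cn(C2OC(CO[Si](C)(C)C(C)(C)C)C3(OS(=O)(=O)C=C3N)C2O[Si](C)(C)C(C)(C)C)c(=O)n(CCCNC(=O)[C@@H](N)C(C)C)c1=O`) carries 1-amino-2-methylpropyl in place of 1-((1-amino-2-methylpropyl)carbonyl)pyrrolidin-2-yl on a carbonyl carbon and so has lost the ring of that group. For the measured compounds named here, no measured step removes this ring, which means the evidence is indirect.

Going by the values given here, three measured steps touch the same side chain. Methyl in place of isopropyl brings a 1.9-fold higher number from compound 1 to compound 2 (0.28 log units; within the scatter) and the reverse swap with the changed ring stereocentre brings a 1.7-fold lower number from compound 2 to compound 3 (0.24 log units; within the scatter) while changing that stereocentre alone brings a 1.1-fold higher number from compound 1 to compound 3 (0.04 log units; within the scatter) as its result. All three steps stayed within the scatter, so no step beyond the scatter is expected in this assay in either direction, although this structural change is larger than any of them and the range must stay wide.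

The expected size is a 1.1-fold higher number from compound 3 to compound 4 (0.04 log units; within the scatter) as the estimate stands. Compound 4 is estimated at 12000 nM with an expected range from 5000 nM to 28000 nM in repeated measurements.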

Compound 4, half-maximal cytotoxic concentration: 9600 nM
Compound 4: the middle estimate sits 1.3-fold (0.10 log units) above what was measured; low and high end bracket the measured number.
By their numbers in this assay, from the lowest: compounds 4, 1, 3 and 2 (each within the scatter of the next).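

In this assay, 1-amino-2-methylpropyl in place of 1-((1-amino-2-methylpropyl)carbonyl)pyrrolidin-2-yl on the carbonyl carbon gives a 1.1-fold lower number from compound 3 to compound 4 (0.06 log units; within the scatter) and a 1.0-fold lower number from compound 1 to compound 4 (0.02 log units; within the scatter) while the same place, starting from 1-((1-aminoethyl)carbonyl)pyrrolidin-2-yl, gives a 2.0-fold lower number from compound 2 to compound 4 (0.30 log units; within the scatter) as its step. The earlier compounds shown here showed only that small edits of this side chain, a methyl for an isopropyl or one changed stereocentre, stay inside the scatter; compound 4 shows that this also holds when the five-membered ring and much of the group are gone, so in this test the ring-bearing groups and 1-amino-2-methylpropyl cannot be told apart at this position. Nothing available bears on this result or offers an explanation for it.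

Still open, on these data alone, is whether a carboxylic acid or a plain alkyl chain in place of 1-amino-2-methylpropyl on this carbonyl carbon would give a number outside the scatter. Also open, as far as these compounds go, is whether the opposite configuration at the stereocentre of 1-amino-2-methylpropyl would do so.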